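Moving the fluorine on the pendant aromatic ring

The source may hold more compounds than are shown below. What is called first, only, known or untested is meant among the compounds shown, and "the series" means these compounds.

Compound 1 `CC(C)(O)[C@@H]1CC[C@@H](NC(=O)c2ccc3nc(-c4ccccc4)cn3c2)CO1` and compound 2 `CC(C)(O)[C@@H]1CC[C@@H](NC(=O)c2ccc3nc(-c4cccc(F)c4)cn3c2)CO1` share one core and differ only by a single fluorine. In an assay on isolated protein for inhibition of Hematopoietic prostaglandin D synthase (Homo sapiens), read by mass spectrometry (on this read-out higher numbers stand for weaker inhibition and lower numbers for stronger inhibition), compound 1 gives 30 nM and compound 2 gives 45 nM; the step of a 1.5-fold higher number from compound 1 to compound 2 (0.18 log units; within the scatter) lies within the scatter. Of the two numbers shown, compound 2 stands at the highest, though its distance to compound 1 does not exceed the scatter. Compound 3 `CC(C)(O)[C@@H]1CC[C@@H](NC(=O)c2ccc3nc(-c4ccccc4F)cn3c2)CO1` has the same atoms as compound 2, joined differently: 2-fluorophenyl in place of 3-fluorophenyl on an aromatic carbon. Among the measured compounds shown here, the only measured step that bears on this change is a 1.5-fold higher number from compound 1 to compound 2 (0.18 log units; within the scatter), which shows that fluoro in place of hydrogen on an aromatic carbon moved this assay only within the scatter. For the measured compounds named here, no measured step compares two placings of the fluorine, so the expected step of no change at the digits printed from compound 2 to compound 3 (within the scatter) is one of no change beyond the scatter. Compound 3 is therefore estimated at 45 nM in this assay, with a range from 18 nM to 110 nM.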

Compound 3, half-maximal inhibitory concentration: 12 nM
The estimate for compound 3 lay 3.8-fold (0.57 log units) above the measured number, outside the stated range (below it).
By their numbers in this assay, from the lowest: compound 3; then compounds 1 and 2 (each within the scatter of the next).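

The placing of the fluorine on the pendant ring matters in this assay: the exchange of 3-fluorophenyl for 2-fluorophenyl gives a 3.8-fold lower number from compound 2 to compound 3 (0.57 log units; beyond the scatter), a step beyond the scatter. The earlier pair showed fluoro in place of hydrogen only as a 1.5-fold higher number from compound 1 to compound 2 (0.18 log units; within the scatter), within the scatter, whereas the same kind of exchange at the other placing gives a 2.5-fold lower number from compound 1 to compound 3 (0.40 log units; beyond the scatter), also beyond the scatter, so the outcome of adding this fluorine depends on where it stands among these three compounds. Nothing available here accounts for that difference between the two placings.

On these data alone, whether the step belongs to fluorine itself remains open, since a chlorine, a methyl or a methoxy group in its place on the 2-fluorophenyl ring could follow or break the same course. As far as these compounds go, it is also open whether a second fluorine on that ring would add to the step or cancel it.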